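The compounds below may be only part of what the source reports. "The series", "measured", "known", "first", "only" and "open" are said of these compounds alone.

Measured in a functional assay on CLL cells (Homo sapiens) for cytotoxicity, read by MTT assay, with a stated time of 48 h; on this read-out higher numbers stand for an effect only at larger amounts of compound and lower numbers for an effect already at smaller amounts:
- Compound 1 `C=C(CC)C(=O)c1ccc(OCC(=O)NCC(=O)O)c(Cl)c1Cl`: > 25000 nM (a limit of the assay, not a number)
- Compound 2 `C=C(CC)C(=O)c1ccc(OCC(=O)NCCCN2CCCC2=O)c(Cl)c1Cl`: 13800 nM
- Compound 3 `C=C(CC)C(=O)c1ccc(OCC(=O)NCO[N+](=O)[O-])c(Cl)c1Cl`: 4100 nM

Compound 3 holds the lowest number here, and the nearest measured comparison is a 3.4-fold lower number from compound 2 to compound 3 (0.53 log units; beyond the scatter). Compound 4 `C=C(CC)C(=O)c1ccc(OCC(=O)NCC2CCC(C(=O)O)CC2)c(Cl)c1Cl` keeps the shared core and changes one group: 4-carboxycyclohexyl in place of nitrooxy on a saturated chain carbon bound to an amide-type nitrogen. The most relevant measured change is an at least 6.0-fold lower number from compound 1 to compound 3 (0.78 log units; beyond the scatter), which replaced carboxy with nitrooxy. Compound 4 brings a carboxy group back, though now as 4-carboxycyclohexyl, so part of that gain is expected to be lost. A higher number than for compound 3 is therefore expected, and the estimate is a 3.7-fold higher number from compound 3 to compound 4 (0.56 log units; beyond the scatter). For compound 4 the estimated value is 15000 nM, with an expected range from 6000 nM to 25000 nM.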

Compound 4, half-maximal effective concentration: 8000 nM
Compound 4: middle estimate off by 1.9-fold (0.27 log units), on the high side, and the stated range covers the measured number.
By their numbers in this assay, from the lowest: compounds 3, 4 and 2 (each within the scatter of the next, the first and the last beyond it). At a limit, above all of these: compound 1.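

In this assay, a carboxy group carried on the 4-carboxycyclohexyl ring gives a measurable number at this place, with an at least 3.1-fold lower number from compound 1 to compound 4 (0.49 log units; beyond the scatter) on the shared core. Nitrooxy is not needed for a number in this range: compound 4 cannot be told apart from compound 3, with a 2.0-fold higher number from compound 3 to compound 4 (0.29 log units; within the scatter) and likewise from compound 2, with a 1.7-fold lower number from compound 2 to compound 4 (0.24 log units; within the scatter) in the same assay. Compound 1, with carboxy directly on the chain carbon, stays at a limit, which is not a number: the limit of > 25000 nM in this assay, at which 1 of the 4 values shown sits.

The compounds shown do not separate the effect of the six-membered ring from that of the carboxy group it carries. From the compounds shown here alone, how a plain cyclohexyl group, a longer chain ending in a carboxylic acid or an amine would fare at this place stays open.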